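Second Fluorine on the Hydrazone Aryl Ring

A few compounds are considered here, and "the series" means these few. Any claim that something is new, unique, unknown or untested is made for them only; others in the source may bear on it.

Measured compounds:
compound 1 `COc1ccc(/C=N/NC(=O)Nc2ccc(Oc3ccnc(-c4nncn4CCN(C)C)c3)c(F)c2)c(OC)c1`: 1680 nM
compound 2 `CN(C)CCn1cnnc1-c1cc(Oc2ccc(NC(=O)N/N=C/c3ccc(F)cc3)cc2F)ccn1`: 1030 nM

In a functional assay on MKN-45 cells (Homo sapiens) for cytotoxicity, read by MTT assay, with a stated time of 72 h (a higher number here means a weaker inhibitor, a lower number a stronger inhibitor), compound 2 gives 1030 nM. Going by the values given here, the only measured step, a 1.6-fold lower number from compound 1 to compound 2 (0.21 log units; within the scatter), is within the scatter, so compound 2 and compound 1 cannot be told apart on these numbers. Compound 3 `CN(C)CCn1cnnc1-c1cc(Oc2ccc(NC(=O)N/N=C/c3ccc(F)cc3F)cc2F)ccn1` differs from compound 2 by fluoro in place of hydrogen on an aromatic carbon. Among the compounds with values here, no measured step shows this change alone; the one step that exists swapped the whole substitution pattern without a shift beyond the scatter. Compound 3 is therefore expected to stay close to compound 2 in this assay, an estimated 1.0-fold lower number from compound 2 to compound 3 (0.01 log units; within the scatter). The estimate for compound 3 is 1000 nM, ranging from 400 nM to 2500 nM.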

Compound 3, half-maximal inhibitory concentration: 810 nM
Estimate against measurement, compound 3: 1.2-fold (0.09 log units) above, within the range that was stated.
By their numbers in this assay, from the lowest: compounds 3, 2 and 1 (each within the scatter of the next, the first and the last beyond it).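

Replacing hydrogen with fluoro, which turns 4-fluorophenyl into 2,4-difluorophenyl, gives in this assay the first view of this single change (a 1.3-fold lower number from compound 2 to compound 3 (0.10 log units; within the scatter)), so the second fluoro brings no readable shift. The wider swap of 2,4-dimethoxyphenyl for 2,4-difluorophenyl does pass the scatter, though modestly (a 2.1-fold lower number from compound 1 to compound 3 (0.32 log units; beyond the scatter)). Nothing measured here explains either step. As far as these compounds go, whether a chloro, a nitrile or a carboxylic acid in place of this second fluoro would give a larger shift remains open.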